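A few compounds are considered here, and "the series" means these few. Any claim that something is new, unique, unknown or untested is made for them only; others in the source may bear on it.

In an assay on Sf21 cells for inhibition of MAP kinase-interacting serine/threonine-protein kinase 1 (Homo sapiens), read by luminescence and ADP-Glo, with stated times of 10 min and 40 min (a lower number here means a stronger inhibitor, a higher number a weaker inhibitor), the two measured compounds stand thus: compound 1 `NC1CCN(C(=O)c2ccc(-c3ccc4ncc(-c5ccc6cnccc6c5)n4c3)cc2)CC1` gives 16.8 nM; compound 2 `O=C(c1ccc(-c2ccc3ncc(-c4ccc5cnccc5c4)n3c2)cc1)N1CCC(N2CCCCC2)CC1` gives 2.4 nM.

Compound 2 holds the lowest of the two numbers, with compound 1 a step away by a 7.0-fold lower number from compound 1 to compound 2 (0.85 log units; beyond the scatter). Compound 3 `N[C@H]1CCCN(C(=O)c2ccc(-c3ccc4ncc(-c5ccc6cnccc6c5)n4c3)cc2)C1` carries 3-aminopiperidin-1-yl in place of 4-(piperidin-1-yl)piperidin-1-yl on a carbonyl carbon. Going by the values given here, this reverses the only measured step, since the amino group of compound 1 returns, now on a different ring carbon. The expectation is therefore a higher number for compound 3 in this assay, a step of about a 6.3-fold higher number from compound 2 to compound 3 (0.80 log units; beyond the scatter), bringing it close to compound 1. The estimate for compound 3 is 15 nM, with a range from 5 nM to 45 nM.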

Compound 3, half-maximal inhibitory concentration: 2.5 nM
Compound 3: middle estimate off by 6.0-fold (0.78 log units), on the high side, outside the stated range (below it).
By their numbers in this assay, from the lowest: compounds 2 and 3 (each within the scatter of the next); then compound 1.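

In this assay the single ring of 3-aminopiperidin-1-yl on the carbonyl carbon serves as well as the two rings of 4-(piperidin-1-yl)piperidin-1-yl, with a 1.0-fold higher number from compound 2 to compound 3 (0.02 log units; within the scatter) as the whole difference. The ring carbon that bears the amino group also matters, since 3-aminopiperidin-1-yl in place of 4-aminopiperidin-1-yl gives a 6.7-fold lower number from compound 1 to compound 3 (0.83 log units; beyond the scatter) and the low number therefore does not depend on the piperidin-1-yl group.

The compounds shown leave open whether the other stereoisomer of 3-aminopiperidin-1-yl, or a hydroxyl group in place of its amino group, would keep this level. Nothing at hand explains these numbers.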